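Carbonyl substituent step from compound 2 to compound 3

The source may hold more compounds than are shown below. What is called first, only, known or untested is meant among the compounds shown, and "the series" means these compounds.

In a functional assay on HT-29 cells (Homo sapiens) for inhibition, read by sulforhodamine B assay, with a stated time of 48 h (a higher number here means a weaker inhibitor of growth, a lower number a stronger inhibitor of growth), compound 2 (`O=CNNC(=O)c1ccc2[nH]c(-c3ccc([N+](=O)[O-])o3)nc2c1`) gives 62.5 ug/mL and has one measured neighbour. Compound 1 (`COc1cccc(C(=O)NNC(=O)c2ccc3[nH]c(-c4ccc([N+](=O)[O-])o4)nc3c2)c1`) gives 31.3 ug/mL and lies within the scatter of it. Compound 3 (`COc1ccc(C(=O)NNC(=O)c2ccc3[nH]c(-c4ccc([N+](=O)[O-])o4)nc3c2)cc1OC`) has 3,4-dimethoxyphenyl in place of hydrogen on a carbonyl carbon. Going by the values given here, one measured step bears on this change, with hydrogen in place of 3-methoxyphenyl at the same carbonyl carbon: a 2.0-fold higher number from compound 1 to compound 2 (0.30 log units; within the scatter) for that swap. Going back to a substituted phenyl is therefore expected to give a small step towards a lower number, with nothing expected beyond the scatter. The estimated step is a 1.8-fold lower number from compound 2 to compound 3 (0.25 log units; within the scatter) in this series. Compound 3 is expected at 35 ug/mL with an estimated range of 14 ug/mL to 80 ug/mL as a working figure.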

Compound 3, concentration for 50% growth inhibition: 15.6 ug/mL
Beside the measured number, compound 3's estimate is 2.2-fold (0.35 log units) above it; the measured number falls inside the stated range.
By their numbers in this assay, from the lowest: compounds 3, 1 and 2 (each within the scatter of the next, the first and the last beyond it).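

In this assay, the carbonyl carbon now shows a step beyond the scatter: 3,4-dimethoxyphenyl in place of hydrogen gives (a 4.0-fold lower number from compound 2 to compound 3 (0.60 log units; beyond the scatter)), whereas the earlier step at this place, involving 3-methoxyphenyl and hydrogen, stayed within it. The added methoxy on the aromatic carbon gives (a 2.0-fold lower number from compound 1 to compound 3 (0.30 log units; within the scatter)), which is within the scatter, so the data do not separate compound 1 from compound 3, and the larger step cannot be assigned to that methoxy rather than to the aryl group as a whole. No measurement in hand accounts for the step from hydrogen to 3,4-dimethoxyphenyl.

On these data alone, it remains open whether a methyl group or a longer alkyl chain on this carbonyl carbon would match compound 3. Also open, as far as these compounds go, is how a phenyl ring carrying an amine or a carboxylic acid would read in this assay.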